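Methylcarbamoyl in Place of Ethyl on the Aryl Ring

The compounds below may be only part of what the source reports. "The series", "measured", "known", "first", "only" and "open" are said of these compounds alone.

Compound 3 `CCc1ccc(N/N=C2\CCC(C)n3c2ncc(C(=O)O)c3=O)cc1` in a functional assay on the whole organism for inhibition, with Rattus norvegicus as the target (a higher number here means that more compound is needed for the effect, a lower number that less compound is needed), gives > 1000 umol/kg, which is a limit of the assay and not a number. Compound 1 `CC1CC/C(=N\Nc2ccc(Br)cc2)c2ncc(C(=O)O)c(=O)n21` likewise reaches only the limit > 1000 umol/kg in this assay. Compound 2 `COc1ccc(N/N=C2\CCC(C)n3c2ncc(C(=O)O)c3=O)cc1` gives 7.6 umol/kg in this assay. The measured steps show an at least 130-fold higher number from compound 2 to compound 3 (2.11 log units; beyond the scatter) and an at least 130-fold lower number from compound 1 to compound 2 (2.11 log units; beyond the scatter), while a step that the two limits leave unreadable from compound 1 to compound 3. Two of the three compounds share the same limit (the limit of > 1000 umol/kg in this assay, at which 2 of the 3 values shown sit), so the methoxy compound is the only one of the three that yields a number.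

Compound 4 `CNC(=O)c1ccc(N/N=C2\CCC(C)n3c2ncc(C(=O)O)c3=O)cc1` differs from compound 3 by methylcarbamoyl in place of ethyl on an aromatic carbon. For the measured compounds named here, no measured step touches a methylcarbamoyl group, so the step from compound 3 to compound 4 rests only on the observation that one change at this position moved the number far while another did not. Compound 4 is therefore expected to sit lower than the limit but with wide uncertainty, estimated at 150 umol/kg within a range from 8 umol/kg to 1000 umol/kg. This expectation amounts to an at least 6.6-fold lower number from compound 3 to compound 4 (0.82 log units; beyond the scatter).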

Compound 4, dose for 50% inhibition: > 100 umol/kg
Compound 4 ended at the assay's limit; the forecaster's own chance of this, stated with the estimate: 40%; the middle value does not contradict the limit.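

With methylcarbamoyl on this aromatic carbon, para to a large group, this assay shows an at least 13-fold higher number from compound 2 to compound 4 (1.11 log units; beyond the scatter), so a replacement for methoxy that brings in nitrogen, oxygen and a hydrogen-bond donor also fails to keep the number of compound 2. Compound 4 gives only a limit of the assay and not a number: the limit of > 100 umol/kg in this assay, at which 1 of the 4 values shown sits. The steps from compound 3 to compound 4 and from compound 1 to compound 4 cannot be read, so methylcarbamoyl cannot be ranked against ethyl or bromo, and among these four groups methoxy alone yields a number.

The compounds shown leave open where compound 4 truly lies beyond its limit. They also leave open whether ethoxy, hydroxy or an amine at this position would yield a number as methoxy does.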